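Swapping the benzyl substituent on an inactive ester

The source may report more compounds than this note shows. Statements on the series, on what has been measured and on what is new or still open speak of the compounds shown alone.

Compound 2 (`COC(=O)[C@H](CCSC)NC(=O)c1ccc(NCc2cncn2Cc2ccccc2C)cc1-c1ccccc1`) has been tested in a functional assay on NIH3T3 cells (Mus musculus); a higher number here means that more compound is needed for the effect, a lower number that less compound is needed. In this assay compound 2 gives only a limit, > 10 uM, not a number. Compound 1 (`CSCC[C@H](NC(=O)c1ccc(NCc2cncn2Cc2ccc(C#N)cc2)cc1-c1ccccc1)C(=O)O`) likewise reaches only a limit in this assay, > 10 uM. Both values rest on (the limit of > 10 uM in this assay, at which 2 of the 2 values shown sit). Compound 3 (`COC(=O)[C@H](CCSC)NC(=O)c1ccc(NCc2cncn2Cc2ccc(C#N)cc2)cc1-c1ccccc1`) has not yet been measured; it carries 4-cyanophenyl in place of 2-methylphenyl on a saturated chain carbon bound to an aromatic nitrogen. Among the measured compounds shown here, no step between two measured compounds is available to guide the size of the change. The step from compound 2 to compound 3 is expected to be a step that the limit leaves unreadable from compound 2 to compound 3, nothing beyond the usual scatter. Compound 3 is estimated at 15 uM, within a range from 5 uM to 50 uM, most likely again reported only as a limit.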

Compound 3, concentration for half-maximal effect: > 10 uM
Compound 3 was reported as a limit; the forecaster's own chance of this, stated with the estimate: 80%; the middle value is on the limit's open side.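

In this assay compound 3 gives only a limit, > 10 uM. Its steps from compound 1 and from compound 2 therefore cannot be read. With no exact value among these compounds, it remains open whether either change alters the concentration needed.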